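From isopropyl to propoxy on the shared core

The source may report more compounds than this note shows. Statements on the series, on what has been measured and on what is new or still open speak of the compounds shown alone.

- compound 1 `CCCc1ccc(-c2cc(=O)c3c(o2)C(CC)(CC)C(=O)C(CC)=C3O)cc1`: 12.2 uM
- compound 2 `CCC1=C(O)c2c(oc(-c3ccc(C(C)C)cc3)cc2=O)C(CC)(CC)C1=O`: 1.08 uM
- compound 3 `CCC1=C(O)c2c(oc(-c3ccc(O)cc3)cc2=O)C(CC)(CC)C1=O`: 20.6 uM

In a functional assay on KBVIN cells (Homo sapiens) for antiproliferative activity, read by sulforhodamine B assay, with a stated time of 3 days (on this read-out lower numbers stand for an effect already at smaller amounts and higher numbers for an effect only at larger amounts of compound), compound 2 has the lowest of the three numbers, and both other compounds lie beyond the scatter from it. Compound 4 `CCCOc1ccc(-c2cc(=O)c3c(o2)C(CC)(CC)C(=O)C(CC)=C3O)cc1` differs from compound 2 in one place: propoxy in place of isopropyl on an aromatic carbon. In words, propoxy stands in place of isopropyl on an aromatic carbon.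

For the measured compounds named here, no measured compound carries propoxy, so the evidence is indirect. Two large steps involve isopropyl: an 11-fold lower number from compound 1 to compound 2 (1.05 log units; beyond the scatter), where it replaces propyl, and a 19-fold higher number from compound 2 to compound 3 (1.28 log units; beyond the scatter), where hydroxy replaces it. Between the other two compounds, a 1.7-fold higher number from compound 1 to compound 3 (0.23 log units; within the scatter) stays within the scatter. Neither replacement of isopropyl measured so far keeps the low number, so a step to a higher number, beyond the scatter but probably somewhat smaller than those two, is expected. The expected change is a 5.6-fold higher number from compound 2 to compound 4 (0.74 log units; beyond the scatter). Compound 4 is estimated at 6 uM, with an expected range from 2 uM to 18 uM.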

Compound 4, concentration for half-maximal effect: 29.2 uM
The estimate for compound 4 lay 4.9-fold (0.69 log units) below the measured number, and the stated range ends below it.
By their numbers in this assay, from the lowest: compound 2; then compounds 1, 3 and 4 (each within the scatter of the next, the first and the last beyond it).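

In this assay, compound 4 adds a third group that fails to keep the low number of isopropyl at this aromatic carbon, with a 27-fold higher number from compound 2 to compound 4 (1.43 log units; beyond the scatter), so compound 2 now stands apart from all three other compounds. Propyl on the oxygen of the hydroxy group leaves the number within the scatter, with a 1.4-fold higher number from compound 3 to compound 4 (0.15 log units; within the scatter), whereas propoxy in place of propyl gives a modest change, with a 2.4-fold higher number from compound 1 to compound 4 (0.38 log units; beyond the scatter), which shows that the oxygen link in the chain counts for a little at this position. Nothing at hand explains why isopropyl differs from these groups.

Going by these compounds, it remains open whether the low number is specific to isopropyl or would also appear with tert-butyl, cyclopropyl or isopropoxy at this place. On these data alone, how an amine or a carboxylic acid there would compare also remains open.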